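A few compounds are considered here, and "the series" means these few. Any claim that something is new, unique, unknown or untested is made for them only; others in the source may bear on it.

Measured in a functional assay on the whole organism (strain Kunming) with Mus musculus as the target, with a stated time of 0.5 h (a lower number here means that less compound is needed, a higher number that more compound is needed for the effect), with each entry a limit of the assay:

- compound 1 `COc1cc(OC)c(OC)cc1/C=C/COC(=O)/C=C/c1c(OC)ccc(OC)c1OC`: > 674 umol/kg
- compound 2 `COc1cc(OC)c(OC)cc1/C=C/COC(=O)/C=C/c1ccccc1C(F)(F)F`: > 710 umol/kg
- compound 3 `COc1cc(OC)c(OC)cc1/C=C/COC(=O)/C=C/c1cc(OC)c(OC)c(OC)c1`: > 450 umol/kg

In this assay compound 2 stands at > 710 umol/kg, which is a limit and not a number. For the measured compounds named here, the two other compounds offer no measured number either, so this short series has no measured dose for half-maximal effect and no measured step between compounds.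

The next compound is compound 4 `COc1ccc(/C=C/C(=O)OC/C=C/c2cc(OC)c(OC)cc2OC)cc1`. It carries 4-methoxyphenyl in place of 2-(trifluoromethyl)phenyl on a double-bonded chain carbon bound to a double-bonded chain carbon. The shared remainder of the structure stays as it is.

Compound 1 also carries methoxy groups on the aromatic ring at this place, and its entry is the limit > 674 umol/kg. Compound 3 carries them too, and its entry is the limit > 450 umol/kg. Neither compound gives reason to expect a clear gain from the new group, so no change beyond the scatter is expected in this assay. The estimated step is an at least 1.1-fold lower number from compound 2 to compound 4 (0.07 log units; that floor lies within the scatter), and it is expected to remain within the scatter. A report of compound 4 as a limit alone would fit this picture. For compound 4 the estimated value is 600 umol/kg, with an expected range from 250 umol/kg to 800 umol/kg.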

Compound 4, dose for half-maximal effect: > 780 umol/kg
Compound 4 ended at the assay's limit; the forecaster's own chance of this, stated with the estimate: 60%; at least 1.3-fold (0.11 log units) between middle value and limit.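

In this assay compound 4 gives > 780 umol/kg, which is a limit and not a number. Compound 2 also stands at a limit, so no step can be read between compound 2 and compound 4. The compounds shown leave open what dose gives half-maximal effect for any of them, and how 4-methoxyphenyl and 2-(trifluoromethyl)phenyl compare.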